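Swapping Fluoro for Methoxy Across Two Related Cores

The source may hold more compounds than are shown below. What is called first, only, known or untested is meant among the compounds shown, and "the series" means these compounds.

Of the compounds shown here, three have so far been tested in an ADME assay on Huh-7 cells (Homo sapiens) for cytotoxicity, read by XTT assay, with a stated time of 3 days, tested at 200 uM; a lower number here means a stronger effect, a higher number a weaker effect of the compound at the concentration tested. Compound 1, `Fc1ccc(-c2cc(-c3ccc4cc(F)ccc4n3)nn2-c2ccccc2)cc1`, gives 89.7%. Compound 2, `COc1ccc(-c2cc(-c3ccc4cc(F)ccc4n3)nn2-c2ccccc2)cc1`, differs from compound 1 in one spot only, namely (methoxy in place of fluoro on an aromatic carbon), and in this assay compound 2 gives 93.7%. The resulting step, a number 4 percentage points higher from compound 1 to compound 2 (within the scatter), is small. Compound 3, `Fc1ccc(-n2nc(-c3ccccc3)cc2-c2ccc3cc(F)ccc3n2)cc1`, is built from the same atoms as compound 1 joined differently; the difference between the two cores is not broken down here. In this assay compound 3 gives 91.6%, close to both compound 1 and compound 2.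

Compound 4, `COc1ccc(-n2nc(-c3ccccc3)cc2-c2ccc3cc(F)ccc3n2)cc1`, has not yet been measured. It relates to compound 3 exactly as compound 2 relates to compound 1: methoxy in place of fluoro on an aromatic carbon. The surroundings of the change read the same in both pairs, so this is the same change carried onto the other core. Because the measured step of a number 4 percentage points higher from compound 1 to compound 2 (within the scatter) stayed within the scatter, the expected step here is a number 2.4 percentage points higher from compound 3 to compound 4 (within the scatter). Compound 4 is accordingly estimated at 94%, with a range from 86% to 100%.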

Compound 4, a percentage reported as activity, at one concentration (the size of the read-out at that concentration, not a potency): 97.4%
For compound 4 the middle estimate is 3.4 percentage points below the measured one; measured number inside the range.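

On the second core, the swap of fluoro for methoxy gives a number 5.8 percentage points higher from compound 3 to compound 4 (within the scatter) in this assay. Set beside the same swap on the first core, the two steps agree as closely as this kind of measurement can tell: the same change on two cores in this assay, a number 4 percentage points higher (within the scatter) from compound 1 to compound 2 and a number 5.8 percentage points higher (within the scatter) from compound 3 to compound 4, 1.8 percentage points apart, within the scatter of two such steps. This shows that, across these four compounds, the change carries from one core to the other without any visible difference, but since neither step stands clear of the scatter, it does not show that the swap itself has a real effect, and two small steps that match say little about how the change would behave on a third core.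

The compounds shown leave open how other groups at this spot, such as an amine, a carboxylic acid or a longer chain like butoxy, would read on either core. They also leave open whether the two cores would stay this alike at lower concentrations or in any other assay.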